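A few compounds are considered here, and "the series" means these few. Any claim that something is new, unique, unknown or untested is made for them only; others in the source may bear on it.

In a functional assay on MCF7 cells (Homo sapiens) for cytotoxicity, read by MTT assay, with a stated time of 48 h (on this read-out higher numbers stand for weaker inhibition and lower numbers for stronger inhibition), compound 1 (`O=C1/C(=C\c2ccccc2)S/C(=N/c2ccccc2)N1Cc1ccncc1`) gives 26400 nM as its measured value, while compound 2 (`COc1ccc(/C=C2/S/C(=N/c3ccccc3)N(Cc3ccncc3)C2=O)cc1OC`) gives 80700 nM and thus holds the higher of the two numbers, marking the weaker inhibition of the pair. Going by the values given here, the only measured step, a 3.1-fold higher number from compound 1 to compound 2 (0.49 log units; beyond the scatter) in this series, is modest and came with 3,4-dimethoxyphenyl in place of phenyl. Compound 3 (`O=C1/C(=C\c2cccc(O)c2)S/C(=N/c2ccccc2)N1Cc1ccncc1`) follows from compound 2 by a single change at that same place, 3-hydroxyphenyl in place of 3,4-dimethoxyphenyl on a double-bonded chain carbon bound to a double-bonded ring carbon here meaning 3-hydroxyphenyl in place of 3,4-dimethoxyphenyl on a double-bonded chain carbon bound to a double-bonded ring carbon. Among the compounds with values here, no measured step covers a hydroxyl group, so the guide is indirect: compound 3 loses the 3,4-dimethoxyphenyl group that accompanied a 3.1-fold higher number from compound 1 to compound 2 (0.49 log units; beyond the scatter) and so should fall back toward compound 1. In this assay the expected change is a 2.5-fold lower number from compound 2 to compound 3 (0.40 log units; beyond the scatter) as estimated here, a lower number and a modest step of nearly the measured size. Compound 3 is estimated at 32000 nM within a range from 12000 nM to 75000 nM for now.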

Compound 3, half-maximal inhibitory concentration: 43600 nM
For compound 3 the middle estimate is 1.4-fold (0.13 log units) below the measured one, and the stated range covers the measured number.
By their numbers in this assay, from the lowest: compounds 1, 3 and 2 (each within the scatter of the next, the first and the last beyond it).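

In this assay, the 3-hydroxyphenyl group at this place, on a double-bonded chain carbon bound to a double-bonded ring carbon, cannot be told apart from either group already seen there: a 1.9-fold lower number from compound 2 to compound 3 (0.27 log units; within the scatter) and a 1.7-fold higher number from compound 1 to compound 3 (0.22 log units; within the scatter) both lie within the usual scatter. Adding a hydroxy group to the phenyl of compound 1 therefore gives no readable change, so a single such substituent at this place has no resolved effect on this read-out, and a 3.1-fold higher number from compound 1 to compound 2 (0.49 log units; beyond the scatter) remains the only difference beyond the scatter among the three compounds. No measurement presented here offers an explanation for these numbers.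

The compounds shown leave open whether an amine or a carboxylic acid on the phenyl group at this place would give a number clearly different from that of compound 1, at 26400 nM, in either direction. They also leave open how a lone methoxy group would compare with the hydroxy group of compound 3 and with the 3,4-dimethoxyphenyl group of compound 2.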